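The source may hold more compounds than are shown below. What is called first, only, known or untested is meant among the compounds shown, and "the series" means these compounds.

Measured compounds:
- compound 1 `O=C(O)c1ccc(-c2cnc(C(=O)CCc3ccc(-c4ccccc4)cc3)o2)cn1` gives 44 nM in an assay for inhibition of Fatty-acid amide hydrolase 1 (Rattus norvegicus); on this read-out higher numbers stand for weaker inhibition and lower numbers for stronger inhibition
- compound 2 `CN(C)C(=O)c1cnc(C(=O)CCc2ccc(-c3ccccc3)cc2)o1` gives 3 nM in this assay

Compound 2 has the lowest of the two numbers in this assay; the nearest is compound 1, and the step of a 15-fold lower number from compound 1 to compound 2 (1.17 log units; beyond the scatter) is beyond the scatter. Compound 3 `NC(=O)c1cccc(-c2cnc(C(=O)CCc3ccc(-c4ccccc4)cc3)o2)n1` is not yet measured. Its change from compound 2 is 6-carbamoylpyridin-2-yl in place of dimethylcarbamoyl on an aromatic carbon. Among the measured compounds shown here, the only measured step that bears on it is a 15-fold lower number from compound 1 to compound 2 (1.17 log units; beyond the scatter), which shows that an aromatic pyridyl group on the shared core gave a clearly higher number than the dimethylcarbamoyl. Compound 3 brings back a pyridyl group at the same position, though with a carbamoyl rather than a carboxylic acid and attached through a different ring carbon. A step upward in this assay is therefore expected, likely smaller than the measured one since compound 3 is not compound 1. The expected step is a 6.7-fold higher number from compound 2 to compound 3 (0.82 log units; beyond the scatter). Compound 3 is estimated at 20 nM, within 5 nM to 80 nM.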

Compound 3, inhibition constant: 1.2 nM
Compound 3: middle estimate off by 17-fold (1.22 log units), on the high side; measured number below the stated range.
By their numbers in this assay, from the lowest: compound 3; then compound 2; then compound 1.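

The position next to the ring oxygen accepts an aromatic ring in this assay: 6-carbamoylpyridin-2-yl in place of dimethylcarbamoyl gives a 2.5-fold lower number from compound 2 to compound 3 (0.40 log units; beyond the scatter), so the higher number of compound 1 does not come with a pyridyl group as such. Between the two pyridyl groups, 6-carbamoylpyridin-2-yl in place of 6-carboxypyridin-3-yl gives a 37-fold lower number from compound 1 to compound 3 (1.56 log units; beyond the scatter), which makes the substituent on the pyridine, its ring attachment, or both decisive here. No measurement available gives a reason for either step.

Still open, going by these compounds, is how that larger step divides between the carbamoyl replacing the carboxylic acid and the change in ring attachment. A 6-carboxypyridin-2-yl group would separate the two, while an unsubstituted pyridin-2-yl group would show what the carbamoyl itself contributes.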